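The source may hold more compounds than are shown below. What is called first, only, known or untested is meant among the compounds shown, and "the series" means these compounds.

Of the compounds shown here, three have been measured in an ADME assay on microsomes from liver (Homo sapiens) for metabolic stability, read by LC-MS, with a stated time of 30 min, tested at 1 uM; on this read-out lower numbers stand for a less stable compound and higher numbers for a more stable compound. Compound 1 `O=C(NCc1ccc(S(=O)(=O)c2ccccc2)cc1)c1cc2ncccc2s1` gives 81% in this assay. Compound 2 `O=C(NCc1ccc(S(=O)(=O)N2CCCCC2)cc1)c1cc2cnccc2s1` gives 15% in this assay, and compound 3 `O=C(NCc1ccc(S(=O)(=O)c2ccccc2)cc1)c1ccc2ccncc2c1` gives 46% in this assay. Compound 2 thus stands lowest of the three: the nearest number, that of compound 3, lies above it by more than the usual scatter, and the furthest, that of compound 1, lies above it by a still wider margin. Compound 2 is therefore the least stable of the three in this assay.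

The step considered here leads from compound 2 to compound 4 `O=C(NCc1ccc(S(=O)(=O)N2CCCCC2)cc1)c1cc2ccncc2o1`, a compound not yet measured. The change is a group of 9 heavy atoms (7 carbon, 1 nitrogen, 1 oxygen; one five-membered aromatic ring with 1 hetero atom, one six-membered aromatic ring with 1 hetero atom) in place of a group of 9 heavy atoms (7 carbon, 1 nitrogen, 1 sulfur; one five-membered aromatic ring with 1 hetero atom, one six-membered aromatic ring with 1 hetero atom), on a carbonyl carbon. The two groups match in size and in the count of donors and acceptors; what differs is that a sulfur in the five-membered aromatic ring gives way to an oxygen.

Among the measured compounds shown here, no pair of measured compounds differs in exactly this way, so there is no directly comparable step to lean on. The expected step of a number 10 percentage points higher from compound 2 to compound 4 (within the scatter) is a modest rise, one that may not exceed the scatter. Compound 4 is expected to give about 25% in this assay, within a range from 8% to 50%.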

Compound 4, percent of the compound remaining: 56%
For compound 4 the middle estimate is 31 percentage points below the measured one; the measured number lies above the stated range.
By their numbers in this assay, from the lowest: compound 2; then compounds 3 and 4 (each within the scatter of the next); then compound 1.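

The group on the carbonyl carbon proves to be a sensitive position: in this assay the exchange gives a number 41 percentage points higher from compound 2 to compound 4 (beyond the scatter) even though the entering and leaving groups match in size and in their counts of donors and acceptors. This is the first pair shown that differs in one place, so it is the first direct sign that a change confined to this group can matter on this read-out, with the piperidine sulfonyl side left as it was. The two structures differ in the five-membered aromatic ring, where oxygen replaces sulfur, and also in where the nitrogen sits in the six-membered aromatic ring, and no information is available to explain the rise or to divide it between these two differences.

The compounds shown leave open how much of the step belongs to the oxygen alone, which would take a pair differing only in that atom. They also leave open whether the same exchange would hold with the phenyl sulfone of compound 1 and compound 3, and whether a small substituent such as a methyl or a fluorine on this group would shift the number further.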